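Cytotoxicity in PC-3 cells: amide-linked piperidine series

The compounds below may be only part of what the source reports. "The series", "measured", "known", "first", "only" and "open" are said of these compounds alone.

Measured so far:
compound 1 `O=C(Nc1cccc(N2CCCC2=O)c1)C1CCCN(C(=O)c2cc(C(F)(F)F)cc(C(F)(F)F)c2)C1` gives 0% in an ADME assay on PC-3 cells (Homo sapiens) for cytotoxicity, read by WST assay, tested at 100 uM; a higher number here means more inhibition at the concentration tested (going by the name of the read-out), a lower number less inhibition
compound 2 `Cc1nc(-c2cccc(C(=O)N3CCCC(C(=O)Nc4ccc(Cl)cc4)C3)c2)no1` gives 0% in this assay

Compound 1 stands level with compound 2 in this assay; the two values lie within the scatter, so no order between them can be drawn. Compound 3 `CC(=O)c1cccc(NC(=O)C2CCCN(C(=O)c3cc(C(F)(F)F)cc(C(F)(F)F)c3)C2)c1` is not yet measured. It differs from compound 1 by acetyl in place of 2-oxopyrrolidin-1-yl on an aromatic carbon. For the measured compounds named here, no step between measured compounds covers this change, and both measured compounds sit at the floor of the read-out. The step of a number 2 percentage points higher from compound 1 to compound 3 (within the scatter) is expected to be none beyond the scatter. For compound 3 the estimated value is 2%, with a range from -8% to 15%.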

Compound 3, a percentage reported as inhibition, at one concentration (the size of the read-out at that concentration, not a potency): 0%
Estimate against measurement, compound 3: 2 percentage points above, within the range that was stated.
By their numbers in this assay, from the lowest: compounds 1, 2 and 3 (each within the scatter of the next).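

In this assay acetyl in place of 2-oxopyrrolidin-1-yl on this aromatic carbon gives no change at the digits printed from compound 1 to compound 3 (within the scatter) and so, for this pair, losing the five-membered non-aromatic ring brings no rise in the read-out. With compound 1 at 0% the pair has no room to show a drop, so only the absence of a rise can be read. No measured evidence bears on a cause for this result.

Going by these compounds, whether an amine or a carboxylic acid on this aromatic carbon would lift the read-out stays open. Also open, on these data alone, is whether any group here can move the read-out off the floor at all.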